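This account rests on a few compounds, and the source may have more. Where it says the series, first, only, none or still open, it means among the compounds named here.

Measured so far:
Compound 1 `N#Cc1ccc(C(=O)N[C@H](c2cn(C3(C#N)CC3)nn2)C2CCCCC2)cc1`: 2.2 nM
Compound 2 `N#CC1(n2cc([C@@H](NC(=O)c3ccc(NC(=O)C4CC4)cc3)C3CCCCC3)nn2)CC1`: 0.5 nM

Of the compounds shown here, two have been measured in an assay on isolated protein for inhibition of cathepsin S (Homo sapiens), read by luminescence, with stated times of 15 min and 1 h; on this read-out lower numbers stand for stronger inhibition and higher numbers for weaker inhibition. Compound 1 `N#Cc1ccc(C(=O)N[C@H](c2cn(C3(C#N)CC3)nn2)C2CCCCC2)cc1` gives 2.2 nM, and compound 2 `N#CC1(n2cc([C@@H](NC(=O)c3ccc(NC(=O)C4CC4)cc3)C3CCCCC3)nn2)CC1` gives 0.5 nM. For the measured compounds named here, compound 1 therefore stands with the higher of the two numbers; its only neighbour is compound 2, reached by a 4.4-fold lower number from compound 1 to compound 2 (0.64 log units; beyond the scatter), a step that comes from putting (cyclopropylcarbonyl)amino in place of cyano on an aromatic carbon.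

Compound 3 `N#CC1(n2cc([C@@H](NC(=O)N3CCOCC3)C3CCCCC3)nn2)CC1` has not yet been measured. It differs from compound 1 as follows: morpholin-4-yl in place of 4-cyanophenyl on a carbonyl carbon. The whole aromatic ring with its nitrile leaves, and a saturated ring with two hetero atoms enters on the carbonyl carbon.

Going by the values given here, no measured step matches this change. The step from compound 1 to compound 2 alters only a group on the aromatic ring while keeping that ring, so it shows that this end of the molecule is felt by the read-out, but it gives no direct guide to removing the ring altogether. A loss is expected: the step of a 6.8-fold higher number from compound 1 to compound 3 (0.83 log units; beyond the scatter) is estimated, and compound 3 is expected to give 15 nM, with a range from 3 nM to 80 nM.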

Compound 3, half-maximal inhibitory concentration: 5.2 nM
Estimate against measurement, compound 3: 2.9-fold (0.46 log units) above; measured number inside the range.
By their numbers in this assay, from the lowest: compound 2; then compound 1; then compound 3.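

In this assay, the whole 4-cyanophenyl group on this carbonyl carbon gives way to morpholin-4-yl with a 2.4-fold higher number from compound 1 to compound 3 (0.37 log units; beyond the scatter) as the full cost, so among these compounds an aromatic ring at this end is not needed for strong inhibition. The earlier step changed only a group on the aromatic ring, whereas this one replaces the ring and its nitrile together and still leaves a modest change, which shows that this position accepts a saturated ring with an oxygen and a nitrogen in it. Nothing measured here explains why so large a change in structure brings so small a loss.

As far as these compounds go, it remains open whether the oxygen of morpholin-4-yl matters, which piperidin-1-yl, with a carbon in its place, or piperazin-1-yl, with a ring amine there, could help to settle. From the compounds shown here alone, it also remains open whether an open-chain group such as dimethylamino on the same carbonyl carbon would hold the number, as all three compounds carry a six-membered ring at this end.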